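Swapping the halogen-bearing ring on the sulfonyl of compound 3

This account rests on a few compounds, and the source may have more. Where it says the series, first, only, none or still open, it means among the compounds named here.

Measured compounds in a functional assay on CHO cells for inhibition of Orexin receptor type 2 (Homo sapiens), read by FLIPR and calcium flux; on this read-out higher numbers stand for weaker inhibition and lower numbers for stronger inhibition:
compound 1, `CCN(CC)C(=O)CN(c1cc(N(CC)CC)ccc1Cl)S(=O)(=O)c1ccc(OC)c(OC)c1`, 2410 nM
compound 2, `CCN(C(=O)CN(c1cc(N(C)C)ccc1Cl)S(=O)(=O)c1ccc(OC)c(OC)c1)c1cccc(C)n1`, 5 nM
compound 3, `CCN(CC)C(=O)CN(c1ccc(C)cc1)S(=O)(=O)c1ccccc1F`, 3370 nM

Compound 3 gives the highest of the three numbers. Its nearest neighbour is compound 1, whose value lies within the scatter of that of compound 3, so the two cannot be ordered. Compound 2 lies far beyond the scatter from compound 3 and is the only one of the three that inhibits strongly.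

Compound 4, `CCN(CC)C(=O)CN(c1ccc(C)cc1)S(=O)(=O)c1cccc(Cl)c1`, differs from compound 3 in one place: 3-chlorophenyl in place of 2-fluorophenyl on a sulfonyl sulfur. Among the compounds with values here, no measured pair shows this change, so no step size is known for it. Compound 4 is expected to stay close to compound 3, with a step of a 1.3-fold lower number from compound 3 to compound 4 (0.13 log units; within the scatter) that need not exceed the scatter. The estimated value of compound 4 is 2500 nM, within 800 nM to 8000 nM.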

Compound 4, half-maximal inhibitory concentration: 139 nM
Compound 4: middle estimate off by 18-fold (1.25 log units), on the high side; the whole stated range lies above it.
By their numbers in this assay, from the lowest: compound 2; then compound 4; then compounds 1 and 3 (each within the scatter of the next).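

In this assay, the group on the sulfonyl sulfur can move the read-out by itself: 3-chlorophenyl in place of 2-fluorophenyl gives a 24-fold lower number from compound 3 to compound 4 (1.38 log units; beyond the scatter), a large step with nothing else altered. The earlier compounds shown here differ from one another in several places and could not isolate this position. Nothing available accounts for the size of this step.

The halogen and its place on the ring change together in this pair, so the compounds shown do not tell which of the two matters. A 3-fluorophenyl or 2-chlorophenyl group on the sulfonyl sulfur would separate them.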